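Fluoro to trifluoromethyl on the aromatic ring

The source may report more compounds than this note shows. Statements on the series, on what has been measured and on what is new or still open speak of the compounds shown alone.

Three compounds of the shared core have numbers in a functional assay on HEK293 cells for negative allosteric modulation of metabotropic glutamate receptor 5 (Homo sapiens), read by calcium flux, with a stated time of 20 min; a higher number here means a weaker inhibitor, a lower number a stronger inhibitor. Compound 1 `CC(C)(C)c1cc2n(n1)CCN(C(=O)c1ccc3ccccc3c1)C2` gives 477 nM. Compound 2 `O=C(c1ccccc1)N1CCn2nc(-c3ccncc3)cc2C1` gives 1290 nM in this assay. Compound 3 `O=C(c1cccc(F)c1)N1CCn2nc(-c3ccc(F)cn3)cc2C1` gives 257 nM in this assay, the lowest of the three numbers; its gap to compound 1 lies within the scatter of repeated measurements, so no order between those two can be read, while its gap to compound 2 lies beyond the scatter. Going by the values given here, compounds 1, 2 and 3 differ from one another in more than one place, so no single-change step among them can be drawn from these numbers.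

Compound 4 `O=C(c1cccc(C(F)(F)F)c1)N1CCn2nc(-c3ccc(F)cn3)cc2C1` is not yet measured. It differs from compound 3 in one place: trifluoromethyl in place of fluoro on an aromatic carbon. Among the compounds with values here, no pair of measured compounds shows this change, so the size of the step has no support in the present numbers. Resting only on the value of compound 3, the step of a 1.0-fold lower number from compound 3 to compound 4 (0.01 log units; within the scatter) is expected to be small, in no fixed direction, and not clearly beyond the scatter. Compound 4 is therefore expected to give 250 nM in this assay, with a range from 90 nM to 700 nM.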

Compound 4, half-maximal inhibitory concentration: 383 nM
Estimate against measurement, compound 4: 1.5-fold (0.19 log units) below, and the stated range covers the measured number.
By their numbers in this assay, from the lowest: compounds 3, 4 and 1 (each within the scatter of the next); then compound 2.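

In this assay the series gains its first single-change step, a 1.5-fold higher number from compound 3 to compound 4 (0.17 log units; within the scatter), with trifluoromethyl in place of fluoro on an aromatic carbon of a six-membered aromatic ring of carbon only, meta to a large group. This change brings in more heavy atoms but gives no readable order between the two compounds, so at this position the numbers do not separate trifluoromethyl from fluoro, and both compounds keep numbers in the same band as each other. No measurement at hand offers a reason for the size of this step.

As far as these compounds go, whether this position accepts other groups on the same terms remains open, for instance a methoxy group, a nitrile, an amine or a carboxylic acid, and so does the effect of leaving this aromatic carbon with hydrogen alone. From the compounds shown here alone, whether the same step would hold with a different group on the other side of the shared core is also open, and the comparisons with compound 1 and compound 2 cannot be read as steps, since those compounds differ from the others in more than one place.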